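Moving the Chlorine: From Compound 2 to Compound 4

A few compounds are considered here, and "the series" means these few. Any claim that something is new, unique, unknown or untested is made for them only; others in the source may bear on it.

Measured so far:
compound 1 `Clc1ccc(-c2nnc(SCCCN3CCN(c4cccc(Cl)c4)CC3)[nH]2)cc1` gives > 300000 nM, a limit of the assay.
compound 2 `Clc1ccc(-c2nnc(SCCCN3CCN(c4ncccn4)CC3)[nH]2)cc1` gives > 300000 nM, also a limit.
compound 3 `Cc1cccc(-c2nnc(SCCCN3CCN(c4ccccn4)CC3)[nH]2)c1` gives > 300000 nM, a limit as well.

In a functional assay on THP-1 cells (Homo sapiens) for cytotoxicity, read by MTT assay, with a stated time of 24 h (a higher number here means a weaker inhibitor, a lower number a stronger inhibitor), compound 2 thus stands only at a limit, as do the other two values, all three sitting at the limit of > 300000 nM in this assay, at which 3 of the 3 values shown sit. The step from compound 1 to compound 2 is a step that the two limits leave unreadable from compound 1 to compound 2. Compound 4 `Clc1cccc(-c2nnc(SCCCN3CCN(c4ncccn4)CC3)[nH]2)c1` differs from compound 2 by 3-chlorophenyl in place of 4-chlorophenyl on an aromatic carbon. Among the measured compounds shown here, no measured step involves this change, and the one recorded step is unreadable; no size can be inferred, and the expectation is simply that compound 4 again reports a limit. The estimated step from compound 2 to compound 4 is a step that the limit leaves unreadable from compound 2 to compound 4. Compound 4 is expected at 400000 nM, within 150000 nM to 2000000 nM.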

Compound 4, half-maximal inhibitory concentration: > 300000 nM
Compound 4 ended at the assay's limit; the forecaster's own chance of this, stated with the estimate: 85%; the middle value does not contradict the limit.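

Compound 2 and compound 4 both stop at a limit, so the move from 4-chlorophenyl to 3-chlorophenyl yields no readable step: the limit of > 300000 nM in this assay, at which 4 of the 4 values shown sit. The compounds shown leave open which change, if any, would give a measurable number instead of that limit.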